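The source may hold more compounds than are shown below. What is called first, only, known or untested is meant among the compounds shown, and "the series" means these compounds.

Measured compounds:
compound 1 `COc1ccc(/C=N/n2c(SC)nnc2-c2cc(OC)c(OC)c(OC)c2)c(OC)c1`: 144000 nM
compound 2 `COc1ccc(/C=N/n2c(SCc3ccc(F)cc3)nnc2-c2cc(OC)c(OC)c(OC)c2)c(OC)c1`: 126000 nM

Both compounds were tested in a functional assay on HT-29 cells (Homo sapiens) for cytotoxicity, read by MTT assay, with a stated time of 48 h; a lower number here means a stronger inhibitor, a higher number a weaker inhibitor. Compound 2 holds the lowest of the two numbers, but its nearest neighbour is compound 1, and the step of a 1.1-fold lower number from compound 1 to compound 2 (0.06 log units; within the scatter) lies within the scatter, so the two cannot be told apart on these numbers. That step put a 4-fluorophenyl in place of hydrogen on a saturated chain carbon bound to a sulfur, without a clear effect.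

Compound 3 `COc1ccc(/C=N/n2c(SCc3ccccc3Cl)nnc2-c2cc(OC)c(OC)c(OC)c2)c(OC)c1` has not yet been measured in this assay. It differs from compound 2 by 2-chlorophenyl in place of 4-fluorophenyl on a saturated chain carbon bound to a sulfur. Within the data shown here, the only measured step touches the same place, and it was within the scatter, so there is no evidence that this part of the molecule moves the number much. The expected step of a 1.0-fold lower number from compound 2 to compound 3 (0.00 log units; within the scatter) is therefore estimated to stay within the scatter, in no particular direction. The estimate for compound 3 in this assay is 125000 nM, with a range from 50000 nM to 310000 nM.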

Compound 3, half-maximal inhibitory concentration: > 200000 nM
Compound 3 ended at the assay's limit; the forecaster's own chance of this, stated with the estimate: 20%; at least 1.6-fold (0.20 log units) between middle value and limit.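

In this assay, compound 3 gives > 200000 nM, which is a limit of the assay and not a number. Swapping the group on a saturated chain carbon bound to a sulfur gives an at least 1.5-fold higher number from compound 2 to compound 3 (0.20 log units; that floor lies within the scatter), and replacing the hydrogen there gives an at least 1.3-fold higher number from compound 1 to compound 3 (0.14 log units; that floor lies within the scatter); each is only a floor within the scatter, but unlike the earlier step, neither has an upper bound. This position can therefore no longer be treated as one where changes are known to have little effect, although the compounds do not show a real difference, and the true size of both steps stays unknown: the limit of > 200000 nM in this assay, at which 1 of the 3 values shown sits.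

From the compounds shown here alone, the change from 4-fluorophenyl to 2-chlorophenyl alters both the halogen and the numbered place it occupies on the ring, so it remains open whether 4-chlorophenyl or 2-fluorophenyl would read more like compound 2 or compound 3. Also open is how this assay would respond to an amine or a carboxylic acid on the same saturated chain carbon bound to a sulfur, as the compounds shown carry only hydrogen or halogen-bearing phenyl groups there.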